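A Ring Swap on the Lowest-Valued Compound

The compounds below may be only part of what the source reports. "The series", "measured", "known", "first", "only" and "open" are said of these compounds alone.

In a functional assay on A20 cells (Mus musculus) for inhibition, with stated times of 1 h, 16 h and 24 h (a lower number here means a stronger inhibitor, a higher number a weaker inhibitor), compound 1 (`CC(C)(C#N)NC(=O)[C@@H]1C[C@@H](S(=O)(=O)c2ccccc2)C[C@H]1C(=O)N1CCOCC1`) gives 43 nM, and compound 2 (`N#CC1(NC(=O)[C@@H]2C[C@@H](S(=O)(=O)c3ccccc3)C[C@H]2C(=O)N2CCOCC2)CCC1`) gives 236 nM. Compound 3 (`C[C@@H]1CN(C(=O)[C@@H]2C[C@H](S(=O)(=O)c3ccccc3)C[C@H]2C(=O)NC2(C#N)CC2)C[C@H](C)O1`) stands lowest of the three at 1 nM. Compound 4 (`N#CC1(NC(=O)[C@@H]2C[C@@H](S(=O)(=O)c3ccccc3)C[C@H]2C(=O)N2CCNCC2)CC1`) differs from it on a carbonyl carbon: piperazin-1-yl in place of 2,6-dimethylmorpholin-4-yl on a carbonyl carbon. For the measured compounds named here, no measured step touches this place. The only one, a 5.5-fold higher number from compound 1 to compound 2 (0.74 log units; beyond the scatter), swaps a group on an amide-type nitrogen, so it serves only as a rough guide to size. Starting from the 1 nM of compound 3, the lowest number seen, a modest rise is expected rather than a further fall. The expected change is a 15-fold higher number from compound 3 to compound 4 (1.18 log units; beyond the scatter). For compound 4 the estimate is 15 nM, with an expected range of 2 nM to 100 nM.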

Compound 4, half-maximal inhibitory concentration: 1340 nM
The estimate for compound 4 lay 89-fold (1.95 log units) below the measured number; the measured number lies above the stated range.
By their numbers in this assay, from the lowest: compound 3; then compound 1; then compound 2; then compound 4.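

In this assay, swapping the group on this carbonyl carbon, piperazin-1-yl in place of 2,6-dimethylmorpholin-4-yl, gives a 1300-fold higher number from compound 3 to compound 4 (3.13 log units; beyond the scatter). For the compounds shown here, that is a far larger move than the only earlier step, a 5.5-fold higher number from compound 1 to compound 2 (0.74 log units; beyond the scatter), which changed a group on an amide-type nitrogen, so the number depends strongly on what sits at this carbonyl carbon. Nothing at hand explains the rise.

As far as these compounds go, whether the ring's second nitrogen or the loss of the two methyl groups matters more stays open. A 4-methylpiperazin-1-yl group on the same carbonyl carbon would bear on this.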